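Thiosemicarbazide tail in place of hydroxyethyl on the core

The source may hold more compounds than are shown below. What is called first, only, known or untested is meant among the compounds shown, and "the series" means these compounds.

Compound 1 `Cc1cc(Nc2ccc(Cl)cc2)nc(SCc2nc3ccccc3[nH]2)n1` gives 28200 nM in a functional assay on MGC-803 cells (Homo sapiens) for cytotoxicity, read by MTT assay, with a stated time of 72 h; a higher number here means a weaker inhibitor, a lower number a stronger inhibitor. Compound 2 `Cc1cc(NCCO)nc(SCc2nc3ccccc3[nH]2)n1` reaches only a limit of this assay, > 100000 nM. Within the data shown here, the single measured step, an at least 3.5-fold higher number from compound 1 to compound 2 (0.54 log units; beyond the scatter), runs toward weaker inhibition and ends at that limit (the limit of > 100000 nM in this assay, at which 1 of the 2 values shown sits). Compound 3 `Cc1cc(NNC(N)=S)nc(SCc2nc3ccccc3[nH]2)n1` differs from compound 2 by a group of 4 heavy atoms (1 carbon, 2 nitrogen, 1 sulfur; no ring) in place of a group of 3 heavy atoms (2 carbon, 1 oxygen; no ring), on a nitrogen on an aromatic ring. Among the measured compounds shown here, no measured step involves such a group, so no direction beyond the scatter can be expected for compound 3, which is expected to stay near the same weak level, a step of an at least 1.1-fold lower number from compound 2 to compound 3 (0.04 log units; that floor lies within the scatter). Compound 3 is therefore estimated at 90000 nM, between 20000 nM and 300000 nM.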

Compound 3, half-maximal inhibitory concentration: > 100000 nM
Compound 3 was reported as a limit (the forecaster's own chance of this, stated with the estimate: 55%); middle value at least 1.1-fold (0.04 log units) away from the limit.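

A second group with no ring on this nitrogen also gives up the measurable activity of compound 1, with an at least 3.5-fold higher number from compound 1 to compound 3 (0.54 log units; beyond the scatter). Compound 3 gives > 100000 nM in this assay, and this is a limit, not a number. How compound 2 and compound 3 compare cannot be read, and the weak end now holds most of the values shown: the limit of > 100000 nM in this assay, at which 2 of the 3 values shown sit.

Only compound 1 carries a ring on this nitrogen. As far as these compounds go, whether an unsubstituted phenyl, a cyclohexyl or a longer alkyl chain there would give a readable value stays open.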